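Compound 3: Swapping Trifluoromethoxy for 4-Fluorophenyl

The source may report more compounds than this note shows. Statements on the series, on what has been measured and on what is new or still open speak of the compounds shown alone.

Compound 1 `CC1(COc2ccc(-c3ccc(F)cc3)cc2)Cn2cc([N+](=O)[O-])nc2O1`: > 64000 nM, a limit
Compound 2 `C[C@]1(COc2ccc(OC(F)(F)F)cc2)Cn2cc([N+](=O)[O-])nc2O1`: > 64000 nM, a limit

In an ADME assay on MRC5 cells (Homo sapiens) for cytotoxicity, read by fluorescence, with a stated time of 72 h (a higher number here means a weaker inhibitor, a lower number a stronger inhibitor), compound 2 gives > 64000 nM, which is a limit and not a number. Compound 2 therefore stands at the limit of > 64000 nM in this assay, at which 2 of the 2 values shown sit. Compound 3 `C[C@]1(COc2ccc(-c3ccc(F)cc3)cc2)Cn2cc([N+](=O)[O-])nc2O1` has 4-fluorophenyl in place of trifluoromethoxy on an aromatic carbon, para to a large group (4-fluorophenyl in place of trifluoromethoxy on an aromatic carbon). With compound 1, which also bears 4-fluorophenyl, at > 64000 nM, a limit, no step beyond the scatter is expected in this assay, in either direction. Compound 3 is estimated at 64000 nM, with an expected range of 30000 nM to 64000 nM.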

Compound 3, half-maximal inhibitory concentration: > 64000 nM
Compound 3: a limit, no number; the forecaster's own chance of this, stated with the estimate: 80%; the middle value sits exactly at the limit.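

No step can be read from compound 1 or compound 2 to compound 3, as all three compounds give a limit and not a number: the limit of > 64000 nM in this assay, at which 3 of the 3 values shown sit.

On these data alone, whether 4-fluorophenyl in place of trifluoromethoxy, or a defined configuration, changes the read-out at all stays open.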